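Swapping the aryl on the carbonyl: a fluorinated analogue

The source may hold more compounds than are shown below. What is called first, only, known or untested is meant among the compounds shown, and "the series" means these compounds.

The three measured compounds share a trimethoxyphenyl-substituted pyrazole core carrying an enone. In a functional assay on T47D cells (Homo sapiens) for cytotoxicity, read by sulforhodamine B assay, with a stated time of 48 h, tested at 0.1 uM (on this read-out higher numbers stand for a weaker effect at the one concentration tested and lower numbers for a stronger effect), compound 1 `COc1cc(-c2cc(/C=C/C(=O)c3ccc(N)cc3)[nH]n2)cc(OC)c1OC` gives 85%, compound 2 `COc1ccc(C(=O)/C=C/c2cc(-c3cc(OC)c(OC)c(OC)c3)n[nH]2)cc1` gives 93%, and compound 3 `COc1cc(C(=O)/C=C/c2cc(-c3cc(OC)c(OC)c(OC)c3)n[nH]2)cc(OC)c1OC` gives 92%. Compound 2 carries the largest of the three numbers, but its gap to compound 3 and its gap to compound 1 both lie within the scatter, so the three cannot be ordered. Among the compounds with values here, the only single-point step on record, a number 8 percentage points higher from compound 1 to compound 2 (within the scatter), is likewise within the scatter.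

Compound 4 `COc1cc(-c2cc(/C=C/C(=O)c3ccc(F)c(F)c3)[nH]n2)cc(OC)c1OC` differs from compound 2 by 3,4-difluorophenyl in place of 4-methoxyphenyl on a carbonyl carbon. Within the data shown here, no measured step replaces the whole aryl group on the carbonyl carbon; the one step that touches that ring, from compound 1 to compound 2, changed only a substituent and moved the number by less than the scatter. On that basis the account expects no step beyond the scatter, a number 4 percentage points lower from compound 2 to compound 4 (within the scatter). Compound 4 is therefore estimated at 89%, within a range from 74% to 100%.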

Compound 4, a percentage reported as activity, at one concentration (the size of the read-out at that concentration, not a potency): 93%
For compound 4 the middle estimate is 4 percentage points below the measured one; low and high end bracket the measured number.
By their numbers in this assay, from the lowest: compounds 1, 3, 2 and 4 (each within the scatter of the next).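

In this assay, exchanging the whole aryl group on the carbonyl carbon, and not just a substituent on it, gives no change at the digits printed from compound 2 to compound 4 (within the scatter), even though a hydrogen-bond acceptor leaves and two fluorines enter. Measured against the 4-aminophenyl group, the 3,4-difluorophenyl group gives a number 8 percentage points higher from compound 1 to compound 4 (within the scatter), so 4-aminophenyl, 4-methoxyphenyl and 3,4-difluorophenyl cannot be told apart at this position. Nothing available speaks to why the read-out stays within the scatter across these aryl groups.

The compounds shown leave open whether a carboxylic acid on this ring, or a saturated ring such as cyclohexyl in place of the aryl group, would move the number beyond the scatter. With only one concentration reported, they also leave open whether these aryl groups differ in potency.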